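The source may report more compounds than this note shows. Statements on the series, on what has been measured and on what is new or still open speak of the compounds shown alone.

In a functional assay on MIA PaCa-2 cells (Homo sapiens) for antiproliferative activity, read by sulforhodamine B assay, with a stated time of 48 h (on this read-out lower numbers stand for stronger inhibition of growth and higher numbers for weaker inhibition of growth), compound 1 `O=C(NCc1cn(Cc2ccc(C(F)(F)F)cc2)nn1)c1cn(-c2ccccc2)nc1-c1ccccc1` gives 17700 nM, the highest of the three numbers available. Compound 2 `COc1ccc(Cn2cc(CNC(=O)c3cn(-c4ccccc4)nc3-c3ccccc3)nn2)cc1OC` gives 8200 nM, and compound 3 `COc1cc(Cn2cc(CNC(=O)c3cn(-c4ccccc4)nc3-c3ccccc3)nn2)cc(OC)c1` gives 190 nM. Both measured changes starting from compound 1 alter the group on a saturated chain carbon bound to an aromatic nitrogen: a 2.2-fold lower number from compound 1 to compound 2 (0.33 log units; beyond the scatter), and a 93-fold lower number from compound 1 to compound 3 (1.97 log units; beyond the scatter). Compound 4 `O=C(NCc1cn(Cc2ccc(C(F)(F)F)cc2)nn1)c1cn(-c2ccccc2)nc1-c1ccc(F)cc1` leaves that group untouched and instead changes the phenyl on the shared core: fluoro in place of hydrogen on an aromatic carbon, para to a large group. Within the data shown here, no measured step touches this position, so the three numbers give no direct guide, and a step within the usual scatter is expected in this assay. Compound 4 is therefore expected to give about 15000 nM, within 6000 nM to 40000 nM, meaning a 1.2-fold lower number from compound 1 to compound 4 (0.07 log units; within the scatter) is expected.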

Compound 4, concentration for 50% growth inhibition: 760 nM
Compound 4: the middle estimate sits 20-fold (1.30 log units) above what was measured; measured number outside the range, below it.
By their numbers in this assay, from the lowest: compound 3; then compound 4; then compound 2; then compound 1.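

In this assay, the phenyl on the shared core proves to be a sensitive position: adding a single fluoro in place of hydrogen gives a 23-fold lower number from compound 1 to compound 4 (1.37 log units; beyond the scatter), a large step from one heavy atom. The group on the chain carbon, which differs among compound 1, compound 2 and compound 3, is therefore not the only place where a small change counts. Nothing measured here explains the size of this step.

Going by these compounds, whether chloro or methoxy in the same place would act like fluoro stays open. So does whether 4-fluorophenyl would help when combined with the 3,5-dimethoxyphenyl group of compound 3.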